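The compounds below may be only part of what the source reports. "The series", "measured", "known", "first", "only" and "open" are said of these compounds alone.

Compound 1 `Cc1cc(Nc2cc(-c3ccccc3)[nH]n2)n2nc(SCC(=O)c3ccccc3)nc2n1` is one of three compounds that share a core and were tested in an ADME assay on GES1 cells (Homo sapiens) for inhibition, read by MTT assay, with a stated time of 72 h (on this read-out lower numbers stand for stronger inhibition and higher numbers for weaker inhibition), where compound 1 gives 33300 nM. Its companions are compound 2 `Cc1cc(Nc2ccn(Cc3csc4ccc(Cl)cc34)n2)n2nc(SCc3ccc(Br)cc3)nc2n1`, which in this assay gives 31400 nM, and compound 3 `Cc1cc(Nc2ccn(Cc3nc(C)c4ccccc4n3)n2)n2nc(SCc3ccc(Br)cc3)nc2n1`, which gives 36800 nM. Compound 1 has the second highest of the three numbers; the other two lie within the scatter of it on either side, so nothing separates the three on this read-out.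

The unmeasured compound 4 `Cc1cc(Nc2cc(-c3ccccc3)[nH]n2)n2nc(SCC3CC3)nc2n1` differs from compound 1 in one place: cyclopropyl in place of benzoyl on a saturated chain carbon bound to a sulfur.

Only one step between measured compounds is shown, a 1.2-fold higher number from compound 2 to compound 3 (0.07 log units; within the scatter), and it concerns a change on a saturated chain carbon bound to an aromatic nitrogen, not the saturated chain carbon bound to a sulfur where compound 4 differs from compound 1. That step gives no direct guide to the present change, though together with the closeness of all three measured numbers it shows that the changes tried so far have left this assay unmoved. With nothing pointing either way, the step expected from compound 1 to compound 4 is none beyond the scatter, a 1.0-fold lower number from compound 1 to compound 4 (0.00 log units; within the scatter). Compound 4 is therefore estimated at 33000 nM in this assay, within a range of 12000 nM to 90000 nM.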

Compound 4, half-maximal inhibitory concentration: > 50000 nM
Compound 4 ended at the assay's limit; the forecaster's own chance of this, stated with the estimate: 15%; middle value at least 1.5-fold (0.18 log units) from the limit.
By their numbers in this assay, from the lowest: compounds 2, 1 and 3 (each within the scatter of the next). At a limit, above all of these: compound 4.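

In this assay, compound 4 gives > 50000 nM, and this value is a limit of the assay, not a number. Cyclopropyl in place of benzoyl on a saturated chain carbon bound to a sulfur, the first change at this place among the compounds shown, gives an at least 1.5-fold higher number from compound 1 to compound 4 (0.17 log units; that floor lies within the scatter), so the floor of this step does not separate the two compounds, and the true size of the step remains unknown. The change brought no lower number in this assay, and compound 4 alone reaches the upper end of the read-out among the compounds shown: the limit of > 50000 nM in this assay, at which 1 of the 4 values shown sits.

The carbonyl and the six-membered aromatic ring leave together in this change, so the compounds shown do not tell whether either one alone matters here; on the same chain carbon, a phenyl group would keep the ring without the carbonyl, and an acetyl group would keep the carbonyl without the ring. Also open, going by these compounds, is how an amine or a carboxylic acid at this place would read in this assay, and whether either would give a number inside the range of the assay.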